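The source may report more compounds than this note shows. Statements on the series, on what has been measured and on what is new or still open speak of the compounds shown alone.

Compound 1, `CC(C)c1ccc(NC(=O)N2CCN(c3ccc(-c4ccccc4)nn3)CC2)cc1`: in an assay on HEK293 cells for inhibition of transient receptor potential cation channel subfamily V member 1 (Homo sapiens), read by FLIPR, at pH 5.5 (on this read-out higher numbers stand for weaker inhibition and lower numbers for stronger inhibition), compound 1 gives > 10000 nM, a limit of the assay rather than a number.
Compound 2, `O=C(Nc1ccc(C(F)(F)F)cc1)N1CCN(c2ccc(-c3ccccc3)nn2)CC1`: in this assay compound 2 gives > 10000 nM, again only a limit.

Going by the values given here, compound 2 therefore stands at the limit of this assay, and so does compound 1; the single measured step, a step that the two limits leave unreadable from compound 1 to compound 2, cannot be read in size, because the limit of > 10000 nM in this assay, at which 2 of the 2 values shown sit, describes both values shown. Compound 3, `O=C(Nc1ccc(OC(F)(F)F)cc1)N1CCN(c2ccc(-c3ccccc3)nn2)CC1`, differs from compound 2 by trifluoromethoxy in place of trifluoromethyl on an aromatic carbon. No measured step separates two numbers that could be compared, so nothing shown gives the direction or size of this change in this assay. The expectation for compound 3 is thus an estimate that rests on compound 2 alone, with its step that the limit leaves unreadable from compound 2 to compound 3 assumed to be no larger than the usual scatter. The estimated value for compound 3 is 15000 nM, in a range from 3000 nM to 60000 nM, most likely reported again as a limit.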

Compound 3, half-maximal inhibitory concentration: > 10000 nM
Compound 3 was reported as a limit; the forecaster's own chance of this, stated with the estimate: 75%; the middle value lies beyond the limit too.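

Going by these compounds alone, no step among compound 1, compound 2 and compound 3 can be read in size, since all three values are limits of the assay rather than numbers: the limit of > 10000 nM in this assay, at which 3 of the 3 values shown sit.
The compounds shown leave open whether swapping the group on the aromatic ring changes the result in this assay at all.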